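Series notes: phenoxy to phenyl swap

The source may report more compounds than this note shows. Statements on the series, on what has been measured and on what is new or still open speak of the compounds shown alone.

Among the compounds with values here, compound 3 `COC(=O)c1cnc(C(=O)CCc2ccc(Oc3ccccc3)cc2)o1` gives 1.7 nM in an assay for inhibition of Fatty-acid amide hydrolase 1 (Rattus norvegicus) (a lower number here means a stronger inhibitor, a higher number a weaker inhibitor), the second highest of the three numbers measured so far. Its closest value is that of compound 2 `COC(=O)c1cc(-c2cnc(C(=O)CCc3ccc(-c4ccccc4)cc3)o2)ccn1`, which gives 1.5 nM, within the scatter of compound 3; the furthest is compound 1 `O=C(O)c1ccc(-c2cnc(C(=O)CCc3ccc(-c4ccccc4)cc3)o2)cn1`, which gives 44 nM, beyond the scatter. Within the data shown here, the only single-place step measured is a 29-fold lower number from compound 1 to compound 2 (1.47 log units; beyond the scatter), a change elsewhere in the structure. Compound 4 `COC(=O)c1cnc(C(=O)CCc2ccc(-c3ccccc3)cc2)o1` differs from compound 3 by phenyl in place of phenoxy on an aromatic carbon. Among the measured compounds shown here, no measured pair bears directly on this change; compounds 1 and 2 already carry phenyl but differ from compound 3 in other respects too. The step of a 1.2-fold higher number from compound 3 to compound 4 (0.07 log units; within the scatter) is therefore expected to stay within the scatter. Compound 4 is estimated at 2 nM, range 0.6 nM to 7 nM.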

Compound 4, inhibition constant: 1.5 nM
The estimate for compound 4 lay 1.3-fold (0.12 log units) above the measured number; the measured number falls inside the stated range.
By their numbers in this assay, from the lowest: compounds 2, 4 and 3 (each within the scatter of the next); then compound 1.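

In this assay, phenyl in place of phenoxy on an aromatic carbon, para to a large group, gives a 1.1-fold lower number from compound 3 to compound 4 (0.05 log units; within the scatter), so the two groups read alike at this position. Methoxycarbonyl in place of 2-(methoxycarbonyl)pyridin-4-yl gives no change at the digits printed from compound 2 to compound 4 (within the scatter), while methoxycarbonyl in place of 6-carboxypyridin-3-yl gives a 29-fold lower number from compound 1 to compound 4 (1.47 log units; beyond the scatter), which leaves compound 1 alone apart from the others. No measurement on hand explains any of these steps.

As far as these compounds go, whether an amine or a benzyl group at the phenoxy position would read the same remains open.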